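The source may hold more compounds than are shown below. What is called first, only, known or untested is meant among the compounds shown, and "the series" means these compounds.

Of the compounds shown here, three that share one core have been measured in a physicochemical assay for solubility, in phosphate buffer, measured as kinetic solubility, with a stated time of 24 h, at pH 6.5; on this read-out lower numbers stand for lower solubility and higher numbers for higher solubility. Compound 1, `Cc1ccc(NC(=O)c2cc(Oc3ccc(S(C)(=O)=O)cc3)cc(OC(C)C)c2)nc1`, gives 1400 nM. Compound 2, `CC(C)Oc1cc(Oc2ccc(S(C)(=O)=O)cc2)cc(-c2cccc(=O)[nH]2)c1`, gives 11000 nM. Compound 3, `Cc1cnc(-c2cc(Oc3ccc(S(C)(=O)=O)cc3)cc(OC(C)C)c2)[nH]c1=O`, gives 1900 nM. Among these three, compound 3 stands second highest: its value and that of compound 1 sit within the scatter of each other, while a 5.8-fold lower number from compound 2 to compound 3 (0.76 log units; beyond the scatter). The remaining measured steps also exchange whole rings on the core: a 7.9-fold higher number from compound 1 to compound 2 (0.90 log units; beyond the scatter), and a 1.4-fold higher number from compound 1 to compound 3 (0.13 log units; within the scatter).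

Compound 4, `CC(C)Oc1cc(Oc2ccc(S(C)(=O)=O)cc2)cc(-c2ncc(Cl)c(=O)[nH]2)c1`, differs from compound 3 in a far smaller way: chloro in place of methyl on an aromatic carbon. The ring itself is kept. For the measured compounds named here, none of the measured steps swaps one single atom for another in this manner, so no step bears directly on this change; all three concern the replacement of an entire ring. With nothing closer to rest on, the expectation is that no change at the digits printed from compound 3 to compound 4 (within the scatter) stays within the scatter, with no clear direction. Compound 4 is therefore estimated at 1900 nM in this assay, with a likely range from 700 nM to 5000 nM.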

Compound 4, solubility: 24000 nM
Compound 4: the middle estimate sits 13-fold (1.10 log units) below what was measured; measured number outside the range, above it.
By their numbers in this assay, from the lowest: compounds 1 and 3 (each within the scatter of the next); then compound 2; then compound 4.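

Within the kept ring, on the aromatic carbon two atoms from the ring nitrogen, putting chloro in place of methyl in this assay gives a large step (a 13-fold higher number from compound 3 to compound 4 (1.10 log units; beyond the scatter)), so one heavy atom at this position can matter a great deal. That single exchange also lifts compound 4 beyond the scatter of both compounds with a different ring (a 2.2-fold higher number from compound 2 to compound 4 (0.34 log units; beyond the scatter); a 17-fold higher number from compound 1 to compound 4 (1.23 log units; beyond the scatter)), making it the highest of the four on this read-out. Nothing measured here accounts for the rise.

As far as these compounds go, it remains open whether a bare hydrogen, fluoro, bromo, methoxy or an amine at this position would give a number closer to that of chloro or of methyl. From the compounds shown here alone, it also remains open whether chloro would have a similar effect on the ring of compound 2.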